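The compounds below may be only part of what the source reports. "The series", "measured", "known", "first", "only" and "open" are said of these compounds alone.

The three measured compounds, all read in a functional assay on MCF7 cells (Homo sapiens) for antiproliferative activity, read by MTT assay, with a stated time of 48 h; on this read-out higher numbers stand for weaker inhibition and lower numbers for stronger inhibition:

Compound 1, `CC(=O)N1N=C(c2ccc3ccccc3c2)OC1c1ccc(Br)cc1`, gives 5.07 ug/mL.
Compound 2, `CC(=O)N1N=C(c2ccc3ccccc3c2)OC1c1ccccc1Cl`, gives 2.36 ug/mL.
Compound 3, `CC(=O)N1N=C(c2ccc3ccccc3c2)OC1c1cccc(F)c1`, gives 1.98 ug/mL.

Compound 3 has the lowest number of the three. Its nearest neighbour is compound 2, a 1.2-fold lower number from compound 2 to compound 3 (0.08 log units; within the scatter), so the two cannot be told apart; compound 1 lies further off, a 2.6-fold lower number from compound 1 to compound 3 (0.41 log units; beyond the scatter). The step followed here leads from compound 3 to compound 4, `CC(=O)N1N=C(c2ccc3ccccc3c2)OC1c1ccc([N+](=O)[O-])cc1`, in which (4-nitrophenyl in place of 3-fluorophenyl on a saturated ring carbon). Among the compounds with values here, no measured step brings in a nitro group, so the guide is indirect: both departures from 4-bromophenyl, a 2.1-fold lower number from compound 1 to compound 2 (0.33 log units; beyond the scatter) and a 2.6-fold lower number from compound 1 to compound 3 (0.41 log units; beyond the scatter), gave modestly lower numbers, and compound 4 moves back toward the 4-bromophenyl pattern of compound 1. A modest rise is therefore expected, with wide uncertainty. Compound 4 is expected to show a 1.6-fold higher number from compound 3 to compound 4 (0.21 log units; within the scatter). The estimate for compound 4 is 3.2 ug/mL, with a range from 1.3 ug/mL to 8 ug/mL.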

Compound 4, half-maximal inhibitory concentration: 7.59 ug/mL
The estimate for compound 4 lay 2.4-fold (0.38 log units) below the measured number; low and high end bracket the measured number.
By their numbers in this assay, from the lowest: compounds 3 and 2 (each within the scatter of the next); then compounds 1 and 4 (each within the scatter of the next).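

Placing 4-nitrophenyl on the saturated ring carbon gives a higher number in this assay than either of the two lowest compounds (a 3.8-fold higher number from compound 3 to compound 4 (0.58 log units; beyond the scatter)) (a 3.2-fold higher number from compound 2 to compound 4 (0.51 log units; beyond the scatter)), with both steps beyond the scatter. Nitro in place of bromo on the aromatic carbon is a step within the scatter (a 1.5-fold higher number from compound 1 to compound 4 (0.18 log units; within the scatter)), so the two groups cannot be told apart here. Among these four compounds, the 4-bromophenyl and 4-nitrophenyl compounds therefore sit together above the 2-chlorophenyl and 3-fluorophenyl compounds, and no compound goes against this split, though each side holds only two compounds.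

As far as these compounds go, whether 4-fluorophenyl would fall with compound 3 or with compound 4 remains open, and that comparison would separate the place of the group from its identity. From the compounds shown here alone, whether 4-aminophenyl would join the 4-bromophenyl and 4-nitrophenyl pair is also open.

Nothing measured here accounts for the split.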